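From Oxetane to Pyrimidine on the Same Aromatic Nitrogen

The compounds below may be only part of what the source reports. "The series", "measured", "known", "first", "only" and "open" are said of these compounds alone.

Two measured compounds share one core and differ only in the group on an aromatic nitrogen. Compound 1 `CN1C(=S)[C@@H](NC(=O)c2nc(Cc3ccccc3)n(CCCCCC#N)n2)COc2ccccc21` carries a 5-cyanopentyl there, and in a functional assay on HT-29 cells (Homo sapiens) for inhibition, read by luminescence and CellTiter-Glo, with a stated time of 24 h (a lower number here means that less compound is needed, a higher number that more compound is needed for the effect), compound 1 gives 3830 nM. Compound 2 `CN1C(=S)[C@@H](NC(=O)c2nc(Cc3ccccc3)n(C3COC3)n2)COc2ccccc21` carries oxetan-3-yl instead; in this assay compound 2 gives 916 nM, the lowest of the two numbers. The step of a 4.2-fold lower number from compound 1 to compound 2 (0.62 log units; beyond the scatter) shows that a change at this position can move the result beyond the scatter. Compound 3 `CN1C(=S)[C@@H](NC(=O)c2nc(Cc3ccccc3)n(-c3ncccn3)n2)COc2ccccc21` has not yet been measured; it differs from compound 2 as follows: pyrimidin-2-yl in place of oxetan-3-yl on an aromatic nitrogen. Within the data shown here, no measured step involves pyrimidin-2-yl, so the one known step is only a loose guide. The expected step is a 1.3-fold higher number from compound 2 to compound 3 (0.12 log units; within the scatter), not clearly beyond the scatter in either direction. The estimate for compound 3 is 1200 nM, within 300 nM to 5000 nM.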

Compound 3, half-maximal effective concentration: 3970 nM
Compound 3: the middle estimate sits 3.3-fold (0.52 log units) below what was measured, within the range that was stated.
By their numbers in this assay, from the lowest: compound 2; then compounds 1 and 3 (each within the scatter of the next).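

Putting pyrimidin-2-yl in place of oxetan-3-yl gives a 4.3-fold higher number from compound 2 to compound 3 (0.64 log units; beyond the scatter) in this assay, so the lower number of compound 2 does not carry over to every ring placed on this aromatic nitrogen. Two very different groups, a chain and a six-membered aromatic ring, give matching results, with a 1.0-fold higher number from compound 1 to compound 3 (0.02 log units; within the scatter), and among these three groups only oxetan-3-yl stands apart. Nothing available here explains this difference.

The compounds shown leave open whether the lower number belongs to oxetan-3-yl alone or would also appear with another non-aromatic ring, such as tetrahydropyran-4-yl. Going by these compounds, how a phenyl ring, a short ethyl chain or a chain ending in an amine would compare at this position also remains open.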